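A few compounds are considered here, and "the series" means these few. Any claim that something is new, unique, unknown or untested is made for them only; others in the source may bear on it.

Measured so far in a physicochemical assay for solubility, using the shake flask method, with a stated time of 12 h; on this read-out lower numbers stand for lower solubility and higher numbers for higher solubility:

Compound 1, `O=C(/C=C/c1ccccc1O)CC(=O)/C=C/c1cccc(O)c1O`: 11000 nM
Compound 2, `O=C(/C=C/c1cccc(O)c1)CC(=O)/C=C/c1cccc(O)c1O`: 8200 nM

Compound 2 gives the smaller of the two numbers, but the gap to compound 1, a 1.3-fold lower number from compound 1 to compound 2 (0.13 log units; within the scatter), lies within the scatter, so the two compounds cannot be told apart on these data. That single step, in which one hydroxyphenyl group replaces another at the same place on the chain, is the only one available, and it produced no shift beyond the scatter.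

Compound 3, `O=C(/C=C/c1ccc(O)cc1)CC(=O)/C=C/c1cccc(O)c1O`, has not yet been measured. It differs from compound 2 in one place: 4-hydroxyphenyl in place of 3-hydroxyphenyl on a double-bonded chain carbon bound to a double-bonded chain carbon. Within the data shown here, this is again an exchange of one hydroxyphenyl group for another at the same chain position, so the step from compound 1 to compound 2 is the only measured step that bears on it. Since that step stayed within the scatter, no change beyond the scatter is expected here either.

Compound 3 is therefore estimated at 8500 nM, with a range from 4000 nM to 18000 nM. The expected step is a 1.0-fold higher number from compound 2 to compound 3 (0.02 log units; within the scatter).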

Compound 3, solubility: 4800 nM
Compound 3: middle estimate off by 1.8-fold (0.25 log units), on the high side, within the range that was stated.
By their numbers in this assay, from the lowest: compounds 3, 2 and 1 (each within the scatter of the next, the first and the last beyond it).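

In this assay, among these compounds, 4-hydroxyphenyl in place of 3-hydroxyphenyl on a double-bonded chain carbon bound to a double-bonded chain carbon gives a 1.7-fold lower number from compound 2 to compound 3 (0.23 log units; within the scatter) and so cannot be told apart from repeat scatter, whereas 4-hydroxyphenyl in place of 2-hydroxyphenyl at that same place gives a 2.3-fold lower number from compound 1 to compound 3 (0.36 log units; beyond the scatter) and is the first step to clear the scatter, though only modestly. The hydroxyphenyl groups at this place are therefore not all interchangeable on this read-out: 2-hydroxyphenyl and 4-hydroxyphenyl can be separated, while 3-hydroxyphenyl lies within the scatter of both. Nothing among the data shown explains the gap between compound 1 and compound 3.

Still open, going by these compounds, is how a plain phenyl, a methoxyphenyl or an aminophenyl at this place would compare with the three hydroxyphenyl groups. Also open, on these data alone, is whether a carboxylic acid or an amine on this ring would shift the number further than these exchanges of one hydroxyphenyl for another, and whether the same gap would appear on a different core.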